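This account rests on a few compounds, and the source may have more. Where it says the series, first, only, none or still open, it means among the compounds named here.

Measured in an assay on isolated protein with Bile acid receptor (Homo sapiens) as the target; a higher number here means that more compound is needed for the effect, a lower number that less compound is needed:
compound 1 `COC(=O)/C=C/c1cccc(N(Cc2ccc(/C=C/c3c(C)cc(C)cc3C)cc2)C(=O)NC(C)C)c1`, 431 nM
compound 2 `COC(=O)/C=C/c1cccc(N(Cc2ccc(-c3ccc(F)c(F)c3)cc2)C(=O)C2CCCCC2)c1`, 72 nM
compound 3 `COC(=O)/C=C/c1cccc(N(Cc2ccc(-c3ccc(SC)cc3)cc2)C(=O)C(C)C)c1`, 51 nM

Compound 3 holds the lowest of the three numbers in this assay; compound 2 sits close to it, within the scatter, while compound 1 stands well apart, beyond it. Compound 4 `COC(=O)/C=C/c1cccc(N(Cc2ccc(-c3cccc(OC(F)(F)F)c3)cc2)C(=O)C(C)C)c1` has not yet been measured. It differs from compound 3 in one place: 3-(trifluoromethoxy)phenyl in place of 4-(methylsulfanyl)phenyl on an aromatic carbon. Among the measured compounds shown here, no measured pair isolates a change of this kind, so the only guide is that compounds 2 and 3, which carry different groups at that position, lie within the scatter of each other. The step from compound 3 to compound 4 in this assay is therefore expected to be small, a 1.6-fold higher number from compound 3 to compound 4 (0.20 log units; within the scatter), if anything toward a higher number. Compound 4 is estimated at 80 nM, between 30 nM and 220 nM.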

Compound 4, half-maximal effective concentration: 247 nM
The estimate for compound 4 lay 3.1-fold (0.49 log units) below the measured number; the measured number lies above the stated range.
By their numbers in this assay, from the lowest: compounds 3 and 2 (each within the scatter of the next); then compounds 4 and 1 (each within the scatter of the next).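

In this assay, this position proves sensitive to the group it carries: 3-(trifluoromethoxy)phenyl in place of 4-(methylsulfanyl)phenyl gives a 4.8-fold higher number from compound 3 to compound 4 (0.69 log units; beyond the scatter) and this step lies beyond the scatter. The earlier compounds shown here offered no pair differing in one place, so they could not show this. No evidence at hand accounts for the step.

This single step changes the substituent and its placing on the ring together, so their contributions remain unseparated. From the compounds shown here alone, how an amine or a carboxylic acid on this ring would behave also remains open.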